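The compounds below may be only part of what the source reports. "The series", "measured", "known", "first", "only" and "open" are said of these compounds alone.

Measured in a physicochemical assay for lipophilicity, measured as octanol-water partition, at pH 7.4; on this read-out lower numbers stand for lower lipophilicity and higher numbers for higher lipophilicity
- compound 1 `Cc1ccc2[nH]c(C(=O)N[C@H]3CN(S(=O)(=O)c4cccnc4)C[C@@H]3C(=O)NCCN(C)C)cc2c1` gives 1.4
- compound 2 `Cc1ccc2[nH]c(C(=O)N[C@H]3CCN(S(=O)(=O)N4CCCCC4)C[C@@H]3C(=O)NCCN(C)C)cc2c1` gives 2.3

Compound 2 stands highest of the two at 2.3 in this assay and compound 1 reads 1.4, a gap beyond the scatter. Within the data shown here, the two differ in more than one place, and no measured pair differs in one place only.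

The next step leads to compound 3 `Cc1ccc2[nH]c(C(=O)N[C@H]3CCN(C(=O)c4cccnc4)C[C@@H]3C(=O)NCCN(C)C)cc2c1` and is (pyridin-3-yl)carbonyl in place of (piperidin-1-yl)sulfonyl on an amine nitrogen in a ring. It puts (pyridin-3-yl)carbonyl in place of (piperidin-1-yl)sulfonyl on an amine nitrogen in a ring, two ring bonds from the ring atom that bears a (2-(dimethylamino)ethyl)carbamoyl group.

The expectation rests on a single comparison, which makes it a rough one. Compound 1 also carries a pyridin-3-yl group and gives 1.4 in this assay, although its core differs from that of compound 3. The expected move is a number 0.90 log units lower from compound 2 to compound 3 (beyond the scatter) and it is estimated to run toward lower numbers, beyond the scatter. For compound 3 the estimated value is 1.4 with an expected range from 1 to 1.8 in this measurement.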

Compound 3, distribution coefficient: 0.7
Estimate against measurement, compound 3: 0.70 log units above; the measured number lies below the stated range.
By their numbers in this assay, from the lowest: compound 3; then compound 1; then compound 2.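

In this assay, placing (pyridin-3-yl)carbonyl in place of (piperidin-1-yl)sulfonyl on the amine nitrogen in the ring gives a number 1.60 log units lower from compound 2 to compound 3 (beyond the scatter). Among these compounds, this is the first step that changes one place only, and it shows that a change at this nitrogen alone, with the rest of the molecule held constant, moves the read-out by a large margin. The hydrogen-bond donors and acceptors counted for the two groups are the same, so those counts do not separate them, and nothing at hand accounts for the size of this step.

The step replaces a six-membered non-aromatic ring with a six-membered aromatic ring and also replaces the sulfonyl link with a carbonyl link, leaving open how much of the shift belongs to each of these two changes. A (piperidin-1-yl)carbonyl group on the same amine nitrogen, with the rest of compound 2 unchanged, would keep the ring of compound 2 and the carbonyl link of compound 3, and so would divide the step into two parts.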